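The source may report more compounds than this note shows. Statements on the series, on what has been measured and on what is new or still open speak of the compounds shown alone.

Measured in a functional assay on NCI-H460 cells (Homo sapiens) for cytotoxicity, read by MTT assay; on this read-out higher numbers stand for weaker inhibition and lower numbers for stronger inhibition:

compound 1 `CCc1cc(S(=O)(=O)N2C[C@H](c3ccccc3)NC2=O)ccc1NC(=O)c1ccc([N+](=O)[O-])cc1`, 800 nM
compound 2 `Cc1cc(S(=O)(=O)N2C(=O)N[C@@H](c3ccccc3)C2C)ccc1NC(=O)c1ccc([N+](=O)[O-])cc1`, reported only as a limit of the assay, > 10000 nM
compound 3 `CCOC(=O)Nc1ccc(S(=O)(=O)N2C[C@H](c3ccccc3)NC2=O)cc1Cl`, 20 nM

Compound 1 holds the highest of the two numbers actually read in this assay. Its nearest neighbour in value is compound 3, which sits a good deal lower, well beyond the scatter of repeated runs. Compound 2 gives no number at all in this assay, only a limit (the limit of > 10000 nM in this assay, at which 1 of the 3 values shown sits).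

The unmeasured compound 4 `CCc1cc(S(=O)(=O)N2C[C@H](c3ccccc3)NC2=O)ccc1NC(=O)NC(C)C` keeps the core of compound 1 and changes a single place: isopropylamino in place of 4-nitrophenyl on a carbonyl carbon. The 4-nitrophenyl group on the carbonyl carbon gives way to isopropylamino, so the (4-nitrophenyl)carbonyl becomes an isopropylcarbamoyl.

Among the compounds with values here, no measured pair differs at exactly this place, so the step has to be judged from the spread of the compounds at hand. Compound 3, the one carrying a small non-aromatic group on its amide-type nitrogen rather than a nitro-bearing aryl carbonyl, gives 20 nM, the low end of the series. On that basis the expected step from compound 1 to compound 4 in this assay is a 2.7-fold lower number from compound 1 to compound 4 (0.43 log units; beyond the scatter), towards a lower number, though modest in size and uncertain. Compound 4 is therefore estimated at 300 nM in this assay, with a plausible range from 50 nM to 3000 nM.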

Compound 4, half-maximal inhibitory concentration: 70 nM
Compound 4: the middle estimate sits 4.3-fold (0.63 log units) above what was measured; the range from low to high includes it.
By their numbers in this assay, from the lowest: compound 3; then compound 4; then compound 1. At a limit, above all of these: compound 2.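

In this assay, within the data shown here, the single change gives an 11-fold lower number from compound 1 to compound 4 (1.06 log units; beyond the scatter) and provides the first direct reading at this place, on a carbonyl carbon whose other neighbour is an amide-type nitrogen. Stronger inhibition on the core of compound 1 therefore does not depend on the 4-nitrophenyl group or on any ring at this place, as the isopropylamino group has no ring and fewer heavy atoms. No measurement shown accounts for the size of this step.

Among these compounds, the single step cannot separate what is lost with the 4-nitrophenyl group from what is gained with the isopropylamino group, or show whether the hydrogen-bond donor that enters matters. From the compounds shown here alone, how a methylamino group, a longer chain such as n-butylamino, or a 4-aminophenyl group would read on the same carbonyl carbon remains open, and with it whether the isopropylamino result reflects a broader trend among small amino groups or is particular to this one group.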